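The source may hold more compounds than are shown below. What is called first, only, known or untested is meant among the compounds shown, and "the series" means these compounds.

In an ADME assay on microsomes from liver (Rattus norvegicus) for metabolic stability (a lower number here means that the compound disappears faster, a higher number that the compound lasts longer), compound 2, `CC(C)C(c1noc(=O)[nH]1)c1ccc(-c2ccc3cccc(F)c3c2)[nH]c1=O`, gives > 3 h. That figure is a limit of the assay and not a number, so compound 2 stands at the upper end of what was recorded (the limit of > 3 h in this assay, at which 1 of the 2 values shown sits). Compound 3, `CC(C)C(Cc1nnn[nH]1)c1ccc(-c2ccc3cccc(F)c3c2)[nH]c1=O`, differs from compound 2 in one place: a group of 6 heavy atoms (2 carbon, 4 nitrogen; one five-membered aromatic ring with 4 hetero atoms) in place of a group of 6 heavy atoms (2 carbon, 2 nitrogen, 2 oxygen; one five-membered aromatic ring with 3 hetero atoms), on a saturated chain carbon bound to an aromatic carbon and a saturated chain carbon. For the measured compounds named here, one measured step bears on this position. Compound 1, `CC(C)NC(=O)CC(c1ccc(-c2ccc3cccc(F)c3c2)[nH]c1=O)C(C)C`, gives < 0.0667 h in this assay, which is again a limit rather than a number (the limit of < 0.0667 h in this assay, at which 1 of the 2 values shown sits). Going from compound 1 to compound 2 brought an at least 44-fold higher number from compound 1 to compound 2 (1.65 log units; beyond the scatter). That step exchanged a chain for a ring, while the step to compound 3 exchanges one ring for another, so a smaller move is expected, most likely staying near the upper limit. Compound 3 is therefore estimated at 2.5 h, with a range from 0.7 h to 6 h. That estimate means a step of an at least 1.2-fold lower number from compound 2 to compound 3 (0.07 log units; that floor lies within the scatter) is expected.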

Compound 3, half-life: 2.08 h
Beside the measured number, compound 3's estimate is 1.2-fold (0.08 log units) above it; measured number inside the range.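

In this assay compound 3 gives a true number, so a result at this position can now be read without a limit on that compound's side. The (1H-tetrazol-5-yl)methyl group keeps most of the rise seen when a ring replaced the amide chain, with an at least 31-fold higher number from compound 1 to compound 3 (1.49 log units; beyond the scatter). Against the five-membered ring with 3 hetero atoms the change gives an at least 1.4-fold lower number from compound 2 to compound 3 (0.15 log units; that floor lies within the scatter), so the two rings cannot yet be told apart. The figure for compound 2 is a limit of the assay and not a number: the limit of > 3 h in this assay, at which 1 of the 3 values shown sits.

The compounds shown leave open how far compound 2 lies past its limit, and so how wide the true gap to compound 3 is. They also leave open how a carboxylic acid, or a longer chain carrying the tetrazole, would behave in this assay.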